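Regioisomeric aryl urea: expectation for compound 3

The source may report more compounds than this note shows. Statements on the series, on what has been measured and on what is new or still open speak of the compounds shown alone.

Measured compounds:
compound 1, `CC(NC(=O)/C=C/c1ccc(NC(=O)Nc2ccc(Cl)c(C(F)(F)F)c2)cc1)c1ccccc1`, 21200 nM
compound 2, `CC1CN(C(=O)/C=C/c2ccc(NC(=O)Nc3ccc(Cl)c(C(F)(F)F)c3)cc2)CC(C)O1`, > 50000 nM

In a functional assay on KETR3 cells (Homo sapiens) for inhibition, read by MTT assay, with a stated time of 120 h (a lower number here means a stronger inhibitor, a higher number a weaker inhibitor), compound 1 gives 21200 nM, the only number shown for this series. Compound 2 reaches only a limit of this assay, > 50000 nM, so its value is not a number; this is the point marked by the limit of > 50000 nM in this assay, at which 1 of the 2 values shown sits. Going by the values given here, the one measured step, an at least 2.3-fold higher number from compound 1 to compound 2 (0.37 log units; beyond the scatter), concerns the carbonyl side of the core and leaves the urea aryl untouched.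

Compound 3, `CC(NC(=O)/C=C/c1ccc(NC(=O)Nc2cc(C(F)(F)F)ccc2Cl)cc1)c1ccccc1`, differs from compound 1 only on the urea: 2-chloro-5-(trifluoromethyl)phenyl in place of 4-chloro-3-(trifluoromethyl)phenyl on an amide-type nitrogen. The two compounds have the same atoms, joined differently. Among the compounds with values here, no measured step bears on a change at this end of the molecule, so there is no evidence from which a direction can be read. Compound 3 is therefore expected to sit close to compound 1, with a step of a 1.3-fold higher number from compound 1 to compound 3 (0.12 log units; within the scatter), within the usual scatter. The estimated value of compound 3 in this assay is 28000 nM, with a range from 10000 nM to 80000 nM.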

Compound 3, half-maximal inhibitory concentration: 14300 nM
Compound 3: the middle estimate sits 2.0-fold (0.29 log units) above what was measured; measured number inside the range.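

Going by these compounds alone, changing the 4-chloro-3-(trifluoromethyl)phenyl group to 2-chloro-5-(trifluoromethyl)phenyl on the amide-type nitrogen gives the first measured step at the urea end of the molecule, and in this assay it comes to a 1.5-fold lower number from compound 1 to compound 3 (0.17 log units; within the scatter). Within the data shown here, in this one pair, the two arrangements of the same atoms on the aryl ring cannot be told apart, so the only step beyond the scatter remains the one on the carbonyl side of the core. Compound 2 is still the one compound at a limit of the assay, which is not a number: the limit of > 50000 nM in this assay, at which 1 of the 3 values shown sits.

The compounds shown leave open what the aryl ring on the urea tolerates beyond these two arrangements, such as a nitrile or a methoxy group in place of the chlorine, or a plain phenyl ring. They also leave open whether this exchange would read the same with the 2,6-dimethylmorpholin-4-yl group on the carbonyl carbon, and how an amine or a carboxylic acid on the (1-phenylethyl)amino group would fare.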